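Bromo Gives Way to Methoxy on the Shared Core

The source may report more compounds than this note shows. Statements on the series, on what has been measured and on what is new or still open speak of the compounds shown alone.

Three compounds share one core, and in an ADME assay on Vero cells (Chlorocebus sabaeus) for cytotoxicity, read by sulforhodamine B assay, with a stated time of 48 h (a lower number here means a stronger inhibitor of growth, a higher number a weaker inhibitor of growth), two of them have a number. Compound 1 `COc1cc(/C(Cl)=C/C=C(\C#N)C(=O)c2c[nH]c3ccccc23)cc(OC)c1OC` carries a hydrogen on the aromatic carbon that matters here; in this assay compound 1 gives 35900 nM. Compound 3 `COc1cc(/C(Cl)=C/C=C(\C#N)C(=O)c2c[nH]c3ccc(Br)cc23)cc(OC)c1OC` carries a bromo on that carbon, and in this assay compound 3 gives 22100 nM. Going by the values given here, the one measured step, a 1.6-fold lower number from compound 1 to compound 3 (0.21 log units; within the scatter), is therefore small. Compound 2 `COc1ccc2[nH]cc(C(=O)/C(C#N)=C/C=C(\Cl)c3ccc(OC)c(OC)c3)c2c1` carries a methoxy on the same carbon but differs from the others elsewhere as well, and for compound 2 this assay reports "not determined" (no result reported). On the numbers shown, compound 3 sits beside compound 1, the two within the scatter of each other.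

The change now made is methoxy in place of bromo on an aromatic carbon, giving compound 4 `COc1ccc2[nH]cc(C(=O)/C(C#N)=C/C=C(\Cl)c3cc(OC)c(OC)c(OC)c3)c2c1`. Among the compounds with values here, only the step of a 1.6-fold lower number from compound 1 to compound 3 (0.21 log units; within the scatter) bears on this change: it altered the same carbon and stayed within the scatter. Within the data shown here, no measured step tells what a methoxy at that carbon does, since compound 2 has no number. The expectation is therefore a step of a 1.4-fold higher number from compound 3 to compound 4 (0.13 log units; within the scatter), no larger than the scatter. For compound 4 in this assay the estimate is 30000 nM, expected to fall between 12000 nM and 75000 nM.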

Compound 4, concentration for total growth inhibition: 12100 nM
For compound 4 the middle estimate is 2.5-fold (0.39 log units) above the measured one; low and high end bracket the measured number.
By their numbers in this assay, from the lowest: compounds 4, 3 and 1 (each within the scatter of the next, the first and the last beyond it).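

In this assay, the exchange of bromo for methoxy gives a 1.8-fold lower number from compound 3 to compound 4 (0.26 log units; within the scatter) and stays within the scatter, so these two groups cannot be told apart at this carbon of the shared core. Measured against hydrogen, however, methoxy gives a 3.0-fold lower number from compound 1 to compound 4 (0.47 log units; beyond the scatter), a modest step but the first at this carbon to pass beyond the scatter, which shows that the number can respond to what sits at this position, while the earlier bromo step alone could not show this. Nothing measured here offers a reason for that shift.

Going by these compounds, whether the shift from hydrogen is particular to methoxy remains open, since an amine, a carboxylic acid or a longer chain such as ethoxy on the same carbon could give a step of a very different size or none at all. Also open, on these data alone, is whether methoxy at this carbon acts the same way when the rest of the molecule changes, as compound 2 differs from compound 4 elsewhere but has no number to compare.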